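Substituent on the anilide ring and growth inhibition in T47D cells

The compounds below may be only part of what the source reports. "The series", "measured", "known", "first", "only" and "open" are said of these compounds alone.

Compound 1: `CN(C)C(=O)c1cc2cnc(Nc3ccc(NC(=O)C4(C(=O)Nc5ccc(Cl)cc5)CC4)cc3)nc2n1C1CCCC1` gives 22.8%
Compound 2: `CN(C)C(=O)c1cc2cnc(Nc3ccc(NC(=O)C4(C(=O)Nc5cccc(F)c5)CC4)cc3)nc2n1C1CCCC1` gives -3.2%
Compound 3: `CN(C)C(=O)c1cc2cnc(Nc3ccc(NC(=O)C4(C(=O)Nc5cccc(C(F)(F)F)c5)CC4)cc3)nc2n1C1CCCC1` gives 9.7%

All three share one core and differ only in the group on the amide-type nitrogen. In a functional assay on T47D cells (Homo sapiens) for inhibition, read by CCK-8 assay, with a stated time of 72 h, tested at 1 uM (a lower number here means less inhibition of growth, a higher number more inhibition of growth at the concentration tested), compound 1 gives the highest of the three numbers, while compound 2 stands lowest: the step of a number 26 percentage points lower from compound 1 to compound 2 (beyond the scatter) and the step of a number 13.1 percentage points lower from compound 1 to compound 3 (beyond the scatter) both fall, and a number 12.9 percentage points higher from compound 2 to compound 3 (beyond the scatter) rises again. Compound 4, `COc1cccc(NC(=O)C2(C(=O)Nc3ccc(Nc4ncc5cc(C(=O)N(C)C)n(C6CCCC6)c5n4)cc3)CC2)c1`, continues from compound 2 with this change: methoxy in place of fluoro on an aromatic carbon. Among the compounds with values here, no measured step swaps fluoro for methoxy, so only the modest moves among compounds 1, 2 and 3 guide the expectation, and a small upward step a number 9.2 percentage points higher from compound 2 to compound 4 (within the scatter) is expected. Compound 4 is therefore estimated at 6%, within -10% to 24%.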

Compound 4, percent growth inhibition at one concentration: 56.3%
Estimate against measurement, compound 4: 50.3 percentage points below; measured number above the stated range.
By their numbers in this assay, from the lowest: compound 2; then compound 3; then compound 1; then compound 4.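

In this assay, within the data shown here, the group meta to a large group on this ring matters far more than the earlier compounds showed: methoxy in place of fluoro gives a number 59.5 percentage points higher from compound 2 to compound 4 (beyond the scatter), and methoxy in place of trifluoromethyl gives a number 46.6 percentage points higher from compound 3 to compound 4 (beyond the scatter). The 3-methoxyphenyl group also outdoes the 4-chlorophenyl group, with a number 33.5 percentage points higher from compound 1 to compound 4 (beyond the scatter), making compound 4 the highest of the four.

Nothing available here explains this jump. As far as these compounds go, whether it is particular to methoxy stays open: ethoxy or a dimethylamino group at the same place would test that.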